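Swapping Methoxy for Methyl on a Fused Core

The source may report more compounds than this note shows. Statements on the series, on what has been measured and on what is new or still open speak of the compounds shown alone.

Of the compounds shown here, three have so far been measured in a functional assay on the whole organism for inhibition, with Digitaria ciliaris as the target, with a stated time of 72 h, tested at 10 mg/L; a lower number here means less inhibition of growth, a higher number more inhibition of growth at the concentration tested. Compound 1 `COc1cc(Cl)nc2n/c(=N/C(=O)c3c(-c4ccc(Cl)cc4Cl)noc3C)sn12` gives 16.5%. Compound 2 `COc1cc(Cl)nc(NC(=S)NC(=O)c2c(-c3ccc(Cl)cc3Cl)noc2C)n1` gives 14.6%, and compound 3 `COc1cc(C)nc(NC(=S)NC(=O)c2c(-c3ccc(Cl)cc3Cl)noc2C)n1` gives 30.2%. On the numbers shown, compound 1 stands second highest of the three; its gap to compound 2 lies within the usual scatter, so nothing separates the two, while compound 3 lies beyond the scatter above it. Within the data shown here, the only step between measured compounds that differ in one place is a number 15.6 percentage points higher from compound 2 to compound 3 (beyond the scatter).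

Compound 4 `Cc1onc(-c2ccc(Cl)cc2Cl)c1C(=O)/N=c1/nc2nc(Cl)cc(C)n2s1` has not yet been measured. It differs from compound 1 in one place: methyl in place of methoxy on an aromatic carbon. Among the measured compounds shown here, no measured step covers this exchange. The step from compound 2 to compound 3 swaps a chloro rather than a methoxy, and it sits on a different core, so it bears only loosely on compound 4; it does show that a single small change on an aromatic carbon can move the number modestly. With no closer guide, the expected step is small. Compound 4 is expected to give 20%, with a range of 5% to 40%. The estimated step of a number 3.5 percentage points higher from compound 1 to compound 4 (within the scatter) is expected to stay within the scatter.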

Compound 4, percent growth inhibition at one concentration: 32.8%
Compound 4: middle estimate off by 12.8 percentage points, on the low side; low and high end bracket the measured number.
By their numbers in this assay, from the lowest: compounds 2 and 1 (each within the scatter of the next); then compounds 3 and 4 (each within the scatter of the next).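

In this assay, among these compounds, methyl in place of methoxy on this aromatic carbon gives a number 16.3 percentage points higher from compound 1 to compound 4 (beyond the scatter), the first sign that the group at this position, next to the ring nitrogen, can shift growth inhibition on the core of compound 1. Among these compounds, this is the second single exchange in which methyl enters on an aromatic carbon and the number rises, after a number 15.6 percentage points higher from compound 2 to compound 3 (beyond the scatter), but that earlier step replaced chloro on a different core, so two cases make only a tentative parallel. The exchange removes one heavy atom and one hydrogen-bond acceptor, yet no measurement shown here accounts for the rise.

On these data alone, it remains open whether the gain is specific to methyl, and an ethyl group, an amine or a plain hydrogen on this carbon would show how closely the number follows the size and kind of group. As far as these compounds go, it is also open whether the same exchange gives a similar step on the core of compound 2, or at test concentrations other than the single one used here.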